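The source may report more compounds than this note shows. Statements on the series, on what has been measured and on what is new or still open speak of the compounds shown alone.

Compound 1 `CC(Cl)/C=C/C(=O)N(Cc1ccc(C(F)(F)F)cc1)CC(C)C` gives 2630 nM
Compound 2 `CC(Cl)/C=C/C(=O)N(Cc1ccc(Cl)cc1)CC(C)C` gives 724 nM
Compound 3 `CC(Cl)/C=C/C(=O)N(Cc1ccc(S(C)(=O)=O)cc1)CC(C)C` is not yet measured

Among the compounds with values here, in a functional assay on the whole organism for inhibition, with Scenedesmus acutus as the target, with a stated time of 20 h (a lower number here means a stronger inhibitor, a higher number a weaker inhibitor), compound 2 gives 724 nM and holds the lowest of the two numbers so far. Within the data shown here, compound 3 keeps the shared core and carries methylsulfonyl in place of chloro on an aromatic carbon as its only change. Among the measured compounds shown here, one measured step bears on this, a 3.6-fold lower number from compound 1 to compound 2 (0.56 log units; beyond the scatter), which came with chloro in place of trifluoromethyl and is modest but beyond the scatter. For the measured compounds named here, no measured compound carries methylsulfonyl, so that step is only a rough guide. It suggests that losing chloro will raise the number by a similar or somewhat larger amount. The expected change is a 5.5-fold higher number from compound 2 to compound 3 (0.74 log units; beyond the scatter) as an estimate. Compound 3 is expected at 4000 nM, with an estimated range from 1000 nM to 16000 nM in this assay once it is tested.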

Compound 3, half-maximal inhibitory concentration: 3090 nM
Compound 3: the middle estimate sits 1.3-fold (0.11 log units) above what was measured; the range from low to high includes it.
By their numbers in this assay, from the lowest: compound 2; then compounds 1 and 3 (each within the scatter of the next).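

In this assay, this position, on an aromatic carbon para to a large group, now has a second replacement for chloro to compare, and methylsulfonyl in place of chloro gives a 4.3-fold higher number from compound 2 to compound 3 (0.63 log units; beyond the scatter) as its step. The earlier pair could not show whether the lower number of compound 2 was tied only to trifluoromethyl as the comparison; here, chloro stands apart from both other groups. Methylsulfonyl and trifluoromethyl are not separated, with a 1.2-fold higher number from compound 1 to compound 3 (0.07 log units; within the scatter) as their step, and no measurement available here accounts for this pattern.

As far as these compounds go, whether a bromine atom, a methoxy group or an amine at this position would match chloro remains open. So does whether chloro keeps its advantage when another part of the shared core changes.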